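Ring Size at the Piperidine Urea in CCR8 Binders

This account rests on a few compounds, and the source may have more. Where it says the series, first, only, none or still open, it means among the compounds named here.

Measured compounds:
compound 1, `Cc1ccccc1C(=O)Nc1ccc(S(=O)(=O)NC2CCN(C(=O)C3CCCC3)CC2)c2ccccc12`, 9.1 nM
compound 2, `Cc1ccccc1C(=O)Nc1ccc(S(=O)(=O)NC2CCN(C(=O)N3CCC3)CC2)c2ccccc12`, 3.5 nM

Going by the values given here, in an assay on L1.2 cells for binding affinity to C-C chemokine receptor type 8 (Homo sapiens) (a higher number here means a weaker inhibitor, a lower number a stronger inhibitor), compound 2 gives the lower of the two numbers measured so far, with compound 1 nearest at a 2.6-fold lower number from compound 1 to compound 2 (0.41 log units; beyond the scatter). Compound 3, `Cc1ccccc1C(=O)Nc1ccc(S(=O)(=O)NC2CCN(C(=O)N3CCCC3)CC2)c2ccccc12`, is the unmeasured neighbour of compound 2. The difference is pyrrolidin-1-yl in place of azetidin-1-yl on a carbonyl carbon. Among the compounds with values here, only one measured step exists, and it exchanges a carbon ring for a nitrogen ring on the same carbonyl carbon (a 2.6-fold lower number from compound 1 to compound 2 (0.41 log units; beyond the scatter)); it does not show what enlarging the nitrogen ring by one atom does. A step the size of a 2.6-fold lower number from compound 1 to compound 2 (0.41 log units; beyond the scatter) is therefore not to be assumed in either direction. Compound 3 is expected to land close to compound 2, with a step of a 1.3-fold higher number from compound 2 to compound 3 (0.11 log units; within the scatter) that stays within the scatter. The estimate for compound 3 is 4.5 nM, with a range from 2 nM to 10 nM.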

Compound 3, inhibition constant: 1.1 nM
Compound 3: middle estimate off by 4.1-fold (0.61 log units), on the high side, and the stated range ends above it.
By their numbers in this assay, from the lowest: compound 3; then compound 2; then compound 1.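

In this assay, the size of the nitrogen ring on the carbonyl carbon matters: pyrrolidin-1-yl in place of azetidin-1-yl gives a 3.2-fold lower number from compound 2 to compound 3 (0.50 log units; beyond the scatter), a change beyond the usual scatter. The new compound also allows a cleaner comparison than the earlier pair. Cyclopentyl and pyrrolidin-1-yl are both five-membered rings, and exchanging the carbon ring for the nitrogen ring gives an 8.3-fold lower number from compound 1 to compound 3 (0.92 log units; beyond the scatter). No available evidence explains why either change lowers the number.

As far as these compounds go, the series stops at the five-membered ring, so it remains open whether a piperidin-1-yl or morpholin-4-yl group on the same carbonyl carbon would lower the number further or raise it again. An open-chain dimethylamino group there would test whether a ring is needed at all.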